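The compounds below may be only part of what the source reports. "The series", "measured", "known", "first", "only" and "open" are said of these compounds alone.

Measured in an ADME assay on NCM460 cells (Homo sapiens) for cytotoxicity, read by CCK-8 assay, with a stated time of 48 h; a lower number here means a stronger inhibitor, a higher number a weaker inhibitor:
- compound 1 `COc1ccc(/C=C\c2cc(OC)c(OC)c(OC)c2)cc1OCc1ccc(C=O)cc1`: 41000 nM
- compound 2 `COc1ccc(/C=C\c2cc(OC)c(OC)c(OC)c2)cc1OCc1ccc(CN[C@H](C(=O)O)[C@H](C)O)cc1`: > 50000 nM (a limit of the assay)
- compound 3 `COc1ccc(/C=C\c2cc(OC)c(OC)c(OC)c2)cc1OCc1ccc(CN2CC[C@H](O)C2)cc1`: 51000 nM

Compound 3 stands level with compound 1 on these numbers, the gap being a 1.2-fold higher number from compound 1 to compound 3 (0.09 log units; within the scatter). The value of compound 2 is a limit, which gives a step that the limit leaves unreadable from compound 2 to compound 3.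

Compound 4 `COc1ccc(/C=C\c2cc(OC)c(OC)c(OC)c2)cc1OCc1ccc(CNCCN(C)C)cc1` is still to be measured. Its difference from compound 3 is (2-(dimethylamino)ethyl)amino in place of 3-hydroxypyrrolidin-1-yl on a saturated chain carbon bound to an aromatic carbon. Read one bond further out, this is (3-hydroxypyrrolidin-1-yl)methyl to ((2-(dimethylamino)ethyl)amino)methyl.

For the measured compounds named here, no measured step makes this exact exchange. The nearest evidence is the two replacements of formyl on an aromatic carbon, an at least 1.2-fold higher number from compound 1 to compound 2 (0.08 log units; that floor lies within the scatter) and a 1.2-fold higher number from compound 1 to compound 3 (0.09 log units; within the scatter). Neither shows a change beyond the scatter, so no step beyond the scatter is expected in this assay, with only a slight lean towards a lower number.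

The expected step is a 1.5-fold lower number from compound 3 to compound 4 (0.16 log units; within the scatter).

For compound 4 the estimate is 35000 nM, with an expected range of 12000 nM to 60000 nM.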

Compound 4, half-maximal inhibitory concentration: 35000 nM
Estimate against measurement, compound 4: no gap at the digits printed; measured number inside the range.
By their numbers in this assay, from the lowest: compounds 4, 1 and 3 (each within the scatter of the next).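

In this assay, the open-chain (2-(dimethylamino)ethyl)amino can take the place of 3-hydroxypyrrolidin-1-yl, with a 1.5-fold lower number from compound 3 to compound 4 (0.16 log units; within the scatter), so at this saturated chain carbon the ring and the defined stereocentre can both go without a change beyond the scatter. The new group also stands level with formyl, with a 1.2-fold lower number from compound 1 to compound 4 (0.07 log units; within the scatter), which leaves compounds 1, 3 and 4 all within the scatter of one another despite their different groups at this place. For compound 2 only a floor can be read, an at least 1.4-fold lower number from compound 2 to compound 4 (0.15 log units; that floor lies within the scatter), as its value is a limit: the limit of > 50000 nM in this assay, at which 1 of the 4 values shown sits.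

As far as these compounds go, whether a longer chain between the two nitrogens, or a piperazine in place of the chain, would move the number beyond the scatter stays open. From the compounds shown here alone, how far the shared core alone sets these numbers also stays open, as all the compounds carry it.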